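The source may report more compounds than this note shows. Statements on the series, on what has been measured and on what is new or still open speak of the compounds shown alone.

Measured so far in an ADME assay on WI-38 cells (Homo sapiens) for cytotoxicity, read by MTT assay, with a stated time of 72 h; on this read-out lower numbers stand for stronger inhibition and higher numbers for weaker inhibition:
Compound 1 `CN(C)CCCn1cnnc1-c1cc(Oc2ccc(NC(=O)Nc3ccc(Cl)c(C(F)(F)F)c3)cc2F)ccn1` gives 7910 nM.
Compound 2 `CN(C)CCCn1cnnc1-c1cc(Oc2ccc(NC(=O)Nc3ccccc3C(F)(F)F)cc2F)ccn1` gives 28600 nM.

Within the data shown here, compound 2 has the higher of the two numbers in this assay; its only neighbour is compound 1, and the step of a 3.6-fold higher number from compound 1 to compound 2 (0.56 log units; beyond the scatter) lies beyond the scatter. Compound 3 `CN(C)CCCn1cnnc1-c1cc(Oc2ccc(NC(=O)Nc3ccc(F)c(F)c3)cc2F)ccn1` has not yet been measured in this assay. It differs from compound 2 in a single place: 3,4-difluorophenyl in place of 2-(trifluoromethyl)phenyl on an amide-type nitrogen. Among the measured compounds shown here, only one measured step bears on this change, a 3.6-fold higher number from compound 1 to compound 2 (0.56 log units; beyond the scatter), in which 4-chloro-3-(trifluoromethyl)phenyl on the amide-type nitrogen gave way to 2-(trifluoromethyl)phenyl and the number rose by a modest amount. Compound 3 moves back to a 3,4-disubstituted ring on that nitrogen, but with two fluorine atoms instead of chlorine and trifluoromethyl, so a partial reversal of that step is expected rather than a full return, giving an estimated step of a 1.9-fold lower number from compound 2 to compound 3 (0.28 log units; within the scatter). With a single step to draw on, the range has to be wide. For compound 3 the estimated value in this assay is 15000 nM, with a range from 6000 nM to 40000 nM.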

Compound 3, half-maximal inhibitory concentration: 15300 nM
Beside the measured number, compound 3's estimate is 1.0-fold (0.01 log units) below it; measured number inside the range.
By their numbers in this assay, from the lowest: compounds 1, 3 and 2 (each within the scatter of the next, the first and the last beyond it).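

In this assay the 3,4-difluorophenyl group on the amide-type nitrogen can be read against two other rings at once: the change gives a 1.9-fold lower number from compound 2 to compound 3 (0.27 log units; within the scatter) and, on the other side, a 1.9-fold higher number from compound 1 to compound 3 (0.29 log units; within the scatter) so neither step separates compound 3 from its neighbour. Among these compounds, the only step at this position that lies beyond the scatter remains a 3.6-fold higher number from compound 1 to compound 2 (0.56 log units; beyond the scatter) and compound 3 now stands within the scatter of both of those compounds, so the three aryl groups do not fall into clearly separate levels, and only the two trifluoromethyl-bearing rings can be told apart. No measurement in hand speaks to what lies behind these numbers.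

All three rings shown on this nitrogen carry fluorine, so it remains open whether a plain phenyl ring, or a ring bearing an amine or a carboxylic acid, would stay within the same span of numbers. Compound 2 and compound 3 also differ in both the substituents and their places on the ring, so the compounds shown cannot separate these two contributions, which a 2-fluorophenyl group on the same nitrogen would begin to address.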